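A few compounds are considered here, and "the series" means these few. Any claim that something is new, unique, unknown or untested is made for them only; others in the source may bear on it.

Measured in a functional assay on IGROV-1 cells (Homo sapiens); a higher number here means a weaker inhibitor of growth, a lower number a stronger inhibitor of growth:
- compound 1 `N=C(NO)NS(=O)(=O)c1cc(-c2nnc(-c3ccc(Cl)cc3)s2)c(Cl)cc1SCc1ccccc1` gives 2570 nM
- compound 2 `COc1cc(CSc2cc(Cl)c(-c3nc(-c4ccccc4)no3)cc2S(=O)(=O)NC(=N)NO)cc(OC)c1OC` gives 5620 nM
- compound 3 `N=C(NO)NS(=O)(=O)c1cc(-c2nc(-c3ccccc3)no2)c(Cl)cc1SCc1ccccc1` gives 2380 nM

Compound 2 stands highest of the three numbers in this assay; compound 1 is the nearest to it and compound 3 the furthest, both gaps beyond the scatter. Compound 4 `COc1cc(CSc2cc(Cl)c(-c3nc(-c4ccc(Cl)cc4)no3)cc2S(=O)(=O)NC(=N)NO)cc(OC)c1OC` has not yet been measured. It differs from compound 2 by chloro in place of hydrogen on an aromatic carbon. Among the measured compounds shown here, the one single-site step among the measured compounds is a 2.4-fold lower number from compound 2 to compound 3 (0.37 log units; beyond the scatter); it concerns the group on the chain carbon bound to sulfur, not the phenyl on the oxadiazole, so it does not bear directly on this change. Compounds 1 and 3 differ in two places rather than one, and their values in this assay lie within the scatter of each other, which gives no sign of a large effect from the chloro. Compound 4 is therefore expected to show a 1.1-fold lower number from compound 2 to compound 4 (0.05 log units; within the scatter), nothing beyond the scatter. Compound 4 is estimated at 5000 nM, with a range from 2500 nM to 10000 nM.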

Compound 4, concentration for 50% growth inhibition: 3800 nM
Compound 4: the middle estimate sits 1.3-fold (0.12 log units) above what was measured, and the stated range covers the measured number.
By their numbers in this assay, from the lowest: compounds 3, 1, 4 and 2 (each within the scatter of the next, the first and the last beyond it).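

Among the compounds shown here, this is the first single-site reading on the phenyl attached to the oxadiazole: in this assay, chloro in place of hydrogen on this aromatic carbon gives a step within the scatter, a 1.5-fold lower number from compound 2 to compound 4 (0.17 log units; within the scatter), where the earlier step concerned only the group on the chain carbon bound to sulfur. The change from phenyl to 4-chlorophenyl therefore shows no separable effect on growth inhibition in the setting of the 3,4,5-trimethoxyphenyl group, and this place accepts the added chlorine without a shift beyond the scatter. No supporting data bear on why the step has this size.

Open, on these data alone, is whether the same change reads alike with phenyl in place of 3,4,5-trimethoxyphenyl on the chain carbon. Also open, as far as these compounds go, is how an amine or a carboxylic acid at this place would compare with chloro.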